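This account rests on a few compounds, and the source may have more. Where it says the series, first, only, none or still open, it means among the compounds named here.

In an in vitro ADME assay on microsomes from liver (Homo sapiens) for pharmacokinetics (a higher number here means faster removal of the compound, a lower number slower removal), compound 1 `Cc1ccc(S(=O)(=O)N2C=CNC(=O)[C@H]2CC(=O)N[C@H]2CCN(C)CC2(C)C)cc1` stands at < 14 mL.min-1.g-1 as a limit of the assay, not a number. Among the compounds with values here, compound 2 `Cc1cc(S(=O)(=O)N2C=CNC(=O)[C@H]2CC(=O)N[C@H]2CCN(C)CC2(C)C)c(C)cc1Cl` gives 87 mL.min-1.g-1 as the only actual number so far. Compound 3 `CN1CC[C@H](NC(=O)C[C@@H]2C(=O)NC=CN2S(=O)(=O)c2cccc(Cl)c2Cl)C(C)(C)C1` differs from it by 2,3-dichlorophenyl in place of 4-chloro-2,5-dimethylphenyl on a sulfonyl sulfur with 2,3-dichlorophenyl in place of 4-chloro-2,5-dimethylphenyl on a sulfonyl sulfur. Within the data shown here, the only measured step at this place is an at least 6.2-fold higher number from compound 1 to compound 2 (0.79 log units; beyond the scatter) and it does not measure this exchange. A small expected move towards a lower number is written as a 2.2-fold lower number from compound 2 to compound 3 (0.34 log units; beyond the scatter) in this estimate. Compound 3 is estimated at 40 mL.min-1.g-1 with an expected range from 16 mL.min-1.g-1 to 100 mL.min-1.g-1 in this assay for now.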

Compound 3, intrinsic clearance in microsomes: 33 mL.min-1.g-1
Estimate against measurement, compound 3: 1.2-fold (0.08 log units) above; the measured number falls inside the stated range.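

In this assay, the substituents on the aryl group at the sulfonyl sulfur can also bring the number down, with a 2.6-fold lower number from compound 2 to compound 3 (0.42 log units; beyond the scatter) for 2,3-dichlorophenyl in place of 4-chloro-2,5-dimethylphenyl. Even so, 2,3-dichlorophenyl does not return to the level of 4-methylphenyl, with an at least 2.3-fold higher number from compound 1 to compound 3 (0.37 log units; beyond the scatter). The size of that step remains only a bound, as compound 1 stands at a limit and not a number: the limit of < 14 mL.min-1.g-1 in this assay, at which 1 of the 3 values shown sits.

The compounds shown do not separate the contribution of each chlorine and methyl on the aryl ring. From the compounds shown here alone, how a pyridyl or methoxyphenyl group on the sulfonyl sulfur would read in this assay also stays open.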